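A few compounds are considered here, and "the series" means these few. Any claim that something is new, unique, unknown or untested is made for them only; others in the source may bear on it.

Measured so far:
- compound 1 `CCN(C[C@H]1Cc2c(cccc2N2CCNCC2)CN1)[C@H]1CCCc2cccnc21`: in a functional assay on CCRF-CEM cells for agonist activity at C-X-C chemokine receptor type 4 (Homo sapiens), read by calcium flux, with a stated time of 25 min (on this read-out higher numbers stand for an effect only at larger amounts of compound and lower numbers for an effect already at smaller amounts), compound 1 gives > 30000 nM, which is a limit of the assay rather than a number.
- compound 2 `CC(C)N(C[C@H]1Cc2c(cccc2N2CCNCC2)CN1)[C@H]1CCCc2cccnc21`: in this assay compound 2 gives > 30000 nM, again a limit of the assay.

Among the measured compounds shown here, compound 2 therefore stands only at a limit, with no number of its own; the one further value shown is also a limit, see (the limit of > 30000 nM in this assay, at which 2 of the 2 values shown sit). For the measured compounds named here, the only measured step, a step that the two limits leave unreadable from compound 1 to compound 2, is left unreadable by the two limits.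

Compound 3 `CCCN(C[C@H]1Cc2c(cccc2N2CCNCC2)CN1)[C@H]1CCCc2cccnc21` differs from compound 2 by propyl in place of isopropyl on an amine nitrogen. Going by the values given here, no measured step bears on this change with a readable size, so nothing in the numbers points to a step beyond the scatter in either direction. Compound 3 is expected to sit where compound 2 sits, most likely again at the limit, with an estimated value of 30000 nM (range 10000 nM to 100000 nM), which means an expected step of a number no higher from compound 2 to compound 3 (the limit leaves the size open).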

Compound 3, half-maximal effective concentration: > 30000 nM
Compound 3 was reported as a limit (the forecaster's own chance of this, stated with the estimate: 85%); the middle value lies on the limit itself.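

Among the compounds shown here, all three values of compound 1, compound 2 and compound 3 in this assay are limits of the assay, and no step among them can be read. The compounds shown leave open whether propyl and isopropyl on the amine nitrogen differ at all, and what any compound here gives as a number.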